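From Aminophenyl to Difluorophenyl at the Carbonyl

The source may report more compounds than this note shows. Statements on the series, on what has been measured and on what is new or still open speak of the compounds shown alone.

compound 1 `COc1cc(-c2cc(/C=C/C(=O)c3ccc(N)cc3)[nH]n2)cc(OC)c1OC`: 2040 nM
compound 2 `COc1ccc(-c2cc(/C=C/C(=O)c3ccc(N)cc3)[nH]n2)cc1`: 2120 nM
compound 3 `COc1cc(C(=O)/C=C/c2cc(-c3cc(OC)c(OC)c(OC)c3)n[nH]2)cc(OC)c1OC`: 1560 nM

Of the compounds shown here, three have been measured in a functional assay on 786-0 cells (Homo sapiens) for inhibition, read by sulforhodamine B assay, with a stated time of 48 h; a higher number here means a weaker inhibitor of growth, a lower number a stronger inhibitor of growth. Compound 1 gives 2040 nM. Compound 2 gives 2120 nM. Compound 3 gives 1560 nM. Compound 1 thus stands in the middle of the three numbers, but its closest neighbour, compound 2, and its furthest, compound 3, both lie within the usual scatter of it, so the three values cannot be told apart.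

The unmeasured compound 4 `COc1cc(-c2cc(/C=C/C(=O)c3ccc(F)c(F)c3)[nH]n2)cc(OC)c1OC` differs from compound 1 in one place: 3,4-difluorophenyl in place of 4-aminophenyl on a carbonyl carbon. Among the compounds with values here, no pair among the measured compounds shows this kind of change, so its effect in this assay has to be guessed without a precedent. The three measured compounds vary at other positions and still sit within the scatter of each other, which gives no sign that the series responds strongly to peripheral changes. For compound 4 the step of a 1.0-fold lower number from compound 1 to compound 4 (0.01 log units; within the scatter) is therefore expected to stay within the scatter, with no clear direction. Compound 4 is estimated at 2000 nM, with a plausible range from 800 nM to 5000 nM.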

Compound 4, concentration for 50% growth inhibition: 3350 nM
Compound 4: middle estimate off by 1.7-fold (0.22 log units), on the low side; measured number inside the range.
By their numbers in this assay, from the lowest: compounds 3, 1, 2 and 4 (each within the scatter of the next, the first and the last beyond it).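

In this assay, within the data shown here, the first step at this position (a 1.6-fold higher number from compound 1 to compound 4 (0.22 log units; within the scatter)) lies within the scatter, so compound 1 and compound 4 cannot be told apart. Among these compounds, on this carbonyl carbon, 4-aminophenyl carries one hydrogen-bond donor and one hydrogen-bond acceptor and 3,4-difluorophenyl carries neither, yet this exchange of groups gives no measurable shift in this single pair, which is the first direct reading of a change at this place. Nothing available explains the size of this step or connects it to any feature of either group.

On these data alone, whether a plain phenyl, or a phenyl carrying a nitrile or a carboxylic acid, would also stay within the scatter of compound 1 remains open, so one step cannot show how tolerant this position is overall. As far as these compounds go, it is also open whether 3,4-difluorophenyl would behave in the same way on the core of compound 2, since this single pair says nothing about whether the result carries over to another core.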